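Shortening a selenium-bound chain: expected effect on growth inhibition

A few compounds are considered here, and "the series" means these few. Any claim that something is new, unique, unknown or untested is made for them only; others in the source may bear on it.

Compound 1 `C[Se]c1nc([Se]C)c2cccnc2n1`: "not determined" (no result reported) in a functional assay on CCRF-CEM cells (Homo sapiens) for cytotoxicity, read by MTT assay, with a stated time of 72 h; a higher number here means a weaker inhibitor of growth, a lower number a stronger inhibitor of growth
Compound 2 `Nc1nc([SeH])nc2ncccc12`: 30900 nM
Compound 3 `CCCCC[Se]c1nc(N)c2cccnc2n1`: 12900 nM

Compound 3 holds the lowest of the two numbers reported in this assay. Within the data shown here, its nearest neighbour is compound 2, and the only step that joins them is a 2.4-fold lower number from compound 2 to compound 3 (0.38 log units; beyond the scatter), a modest but real change when pentyl took the place of hydrogen on a selenium. Compound 1 was tested in no way that gave a number, so it cannot guide the comparison.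

Compound 4 `C[Se]c1nc(N)c2cccnc2n1` differs from compound 3 by hydrogen in place of butyl on a saturated chain carbon bound to a selenium atom; read one bond further out, pentyl becomes methyl. The change therefore walks part of the way back from compound 3 toward compound 2, and the step from compound 2 to compound 3 is the only measured one that bears on it. Since that step was modest, the expected shift for compound 4 in this assay is a 1.6-fold higher number from compound 3 to compound 4 (0.19 log units; within the scatter), toward a higher number, and it may well stay inside the scatter.

The estimate for compound 4 in this assay is 20000 nM, with a likely range from 8000 nM to 50000 nM.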

Compound 4, concentration for 50% growth inhibition: 68400 nM
Estimate against measurement, compound 4: 3.4-fold (0.53 log units) below; measured number above the stated range.
By their numbers in this assay, from the lowest: compound 3; then compound 2; then compound 4.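

The selenium substituent in this assay does not act as a simple scale running from hydrogen up to pentyl: the change from hydrogen to methyl on a selenium gives a 2.2-fold higher number from compound 2 to compound 4 (0.35 log units; beyond the scatter), whereas the change from hydrogen to pentyl gave a 2.4-fold lower number from compound 2 to compound 3 (0.38 log units; beyond the scatter). The two alkyl groups therefore move the number in opposite directions from compound 2, which sits between them. Cutting pentyl back to methyl gives a 5.3-fold higher number from compound 3 to compound 4 (0.72 log units; beyond the scatter), a larger step than either of the other two, so this position responds more to the change between the two chains than the earlier pair could show, and no measurement shown here explains why.

Going by these compounds, with only methyl and pentyl as chains, it remains open where along the series from methyl to pentyl the number crosses that of compound 2, and whether ethyl, propyl or butyl would fall on a smooth path between them. On these data alone, it is equally open whether a longer chain such as octyl, or a chain ending in a carboxylic acid or an amine, would lower the number further.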